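This account rests on a few compounds, and the source may have more. Where it says the series, first, only, none or still open, it means among the compounds named here.

Measured so far:
compound 1, `COC(=O)c1cc(Cl)ccc1OC(=O)COc1cc(O)c2c(=O)cc(-c3ccccc3)oc2c1`: 3740 nM
compound 2, `C=C(CCc1cc(O)c2c(=O)cc(-c3ccccc3)oc2c1)Cc1c(Br)cccc1C(=O)CC`: 40700 nM
compound 3, `COC(=O)c1cc(O)ccc1OC(=O)COc1cc(O)c2c(=O)cc(-c3ccccc3)oc2c1`: 29500 nM

In a functional assay on cells (T-cell, Mus musculus, strain BALB/c) for inhibition, read by MTT assay, with a stated time of 72 h (a higher number here means a weaker inhibitor, a lower number a stronger inhibitor), compound 1 stands lowest of the three numbers. Among the measured compounds shown here, the single counted step, a 7.9-fold higher number from compound 1 to compound 3 (0.90 log units; beyond the scatter), concerns hydroxy in place of chloro on an aromatic carbon. For the measured compounds named here, compound 2 gives 40700 nM; no one-place step links it to compound 1, so only the two values themselves can be set side by side.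

Compound 4, `COC(=O)c1ccc(Cl)cc1OC(=O)COc1cc(O)c2c(=O)cc(-c3ccccc3)oc2c1`, differs from compound 1 by 5-chloro-2-(methoxycarbonyl)phenyl in place of 4-chloro-2-(methoxycarbonyl)phenyl on an oxygen next to a carbonyl group. Going by the values given here, no measured step bears on this change: the one counted step, a 7.9-fold higher number from compound 1 to compound 3 (0.90 log units; beyond the scatter), swaps the chloro for hydroxy rather than moving the chloro within the group. With nothing to support a directed shift, the expected step of a 1.3-fold higher number from compound 1 to compound 4 (0.13 log units; within the scatter) is none beyond the scatter. Compound 4 is estimated at 5000 nM, with a range of 1500 nM to 17000 nM.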

Compound 4, half-maximal inhibitory concentration: 12400 nM
The estimate for compound 4 lay 2.5-fold (0.39 log units) below the measured number; the range from low to high includes it.
By their numbers in this assay, from the lowest: compound 1; then compound 4; then compounds 3 and 2 (each within the scatter of the next).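

Where the chloro sits on the phenyl ester matters, even with the same atoms: the change gives a 3.3-fold higher number from compound 1 to compound 4 (0.52 log units; beyond the scatter). Compound 4 still retains an advantage over the hydroxy compound, with a 2.4-fold lower number from compound 3 to compound 4 (0.38 log units; beyond the scatter), so the chloro isomer loses only part of the gain seen with compound 1. No available measurement explains the effect of moving the chloro.

Still open, going by these compounds, is how a fluoro or methoxy group on this phenyl would compare with the chloro. The effect of a carboxylic acid in place of the methoxycarbonyl is also unresolved.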